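Nitro substitution on the benzoyl arm of the thiourea series

A few compounds are considered here, and "the series" means these few. Any claim that something is new, unique, unknown or untested is made for them only; others in the source may bear on it.

Compound 1 `O=C(NC(=S)Nc1nc2ccccc2s1)c1ccccc1` carries a benzoyl group on the thiourea that links to the shared core. Among the measured compounds shown here, in a functional assay on HeLa cells (Homo sapiens) for cytotoxicity, read by MTT assay, with a stated time of 24 h (a higher number here means a weaker inhibitor, a lower number a stronger inhibitor), compound 1 gives 57500 nM, the highest of the two numbers measured so far; the nearest neighbour is compound 2 `O=C(NC(=S)Nc1nc2ccccc2s1)N1CCOCC1`, which in this assay gives 51800 nM. For the measured compounds named here, the one step recorded, a 1.1-fold lower number from compound 1 to compound 2 (0.05 log units; within the scatter), lies within the scatter, so swapping the phenyl on the carbonyl carbon for morpholin-4-yl leaves the read-out essentially unchanged.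

Compound 3 `O=C(NC(=S)Nc1nc2ccccc2s1)c1ccc([N+](=O)[O-])cc1` is not yet measured. Going by the values given here, it differs from compound 1 by nitro in place of hydrogen on an aromatic carbon, a change placed on the six-membered ring of carbon only, a position on which no measured step gives direct information. Among the compounds with values here, the only available step, from compound 1 to compound 2, alters the whole carbonyl substituent rather than a ring hydrogen and is itself flat. With nothing pointing either way, no step beyond the scatter is expected in this assay for compound 3; the expected change is a 1.2-fold lower number from compound 1 to compound 3 (0.06 log units; within the scatter). Compound 3 is thus estimated at 50000 nM in this assay, with a range from 15000 nM to 160000 nM.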

Compound 3, half-maximal inhibitory concentration: 62600 nM
For compound 3 the middle estimate is 1.3-fold (0.10 log units) below the measured one; the range from low to high includes it.
By their numbers in this assay, from the lowest: compounds 2, 1 and 3 (each within the scatter of the next).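

In this assay, the place on the six-membered aromatic ring of carbon only, para to a large group, now has its first direct reading, and nitro in place of hydrogen there gives a 1.1-fold higher number from compound 1 to compound 3 (0.04 log units; within the scatter) as the whole change. The series therefore now holds two single changes starting from compound 1, one on the ring and one replacing the entire phenyl on the carbonyl carbon (a 1.1-fold lower number from compound 1 to compound 2 (0.05 log units; within the scatter)), and neither step leaves the scatter. No measurement in hand speaks to why the nitro group leaves the read-out flat in these cells.

Open, as far as these compounds go, is whether an amine or a carboxylic acid at the same place on the ring would stay as flat as nitro does, given that a single ring substituent is all that has been read there so far. Also open, from the compounds shown here alone, is whether a longer chain in place of the phenyl on the carbonyl carbon, or a change on the shared core itself, would produce any step beyond the scatter.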